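Triazine series: chloro for methoxy at the ring carbon

The compounds below may be only part of what the source reports. "The series", "measured", "known", "first", "only" and "open" are said of these compounds alone.

Measured so far: compound 1 `CNc1nc(NC2(C#N)CCCCC2)nc(-n2ccnc2)n1` with 1050 nM in an in vitro assay on Sf21 cells for inhibition of high affinity 3',5'-cyclic-AMP phosphodiesterase 7A (Homo sapiens); a higher number here means a weaker inhibitor, a lower number a stronger inhibitor; compound 2 `CNc1nc(NC2(C#N)CCCCC2)nc(OC)n1` with 521 nM in this assay.

Compound 2 gives the lowest of the two numbers, but the step of a 2.0-fold lower number from compound 1 to compound 2 (0.30 log units; within the scatter) is within the scatter, so the two compounds cannot be ranked against each other. The next compound, compound 3 `CNc1nc(Cl)nc(NC2(C#N)CCCCC2)n1`, carries chloro in place of methoxy on an aromatic carbon. Within the data shown here, no measured step in this set exchanges a methoxy for a chloro at that position; the only step at this carbon, a 2.0-fold lower number from compound 1 to compound 2 (0.30 log units; within the scatter), swapped a different group and stayed within the scatter. On that basis no step beyond the scatter is expected for a 1.1-fold higher number from compound 2 to compound 3 (0.02 log units; within the scatter), in either direction. Compound 3 is therefore estimated at 550 nM in this assay, with a range from 180 nM to 1700 nM; the range is wide because the prior a 2.0-fold lower number from compound 1 to compound 2 (0.30 log units; within the scatter) gives no direct guide to a chloro substituent.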

Compound 3, half-maximal inhibitory concentration: 1070 nM
Beside the measured number, compound 3's estimate is 1.9-fold (0.29 log units) below it; low and high end bracket the measured number.
By their numbers in this assay, from the lowest: compounds 2, 1 and 3 (each within the scatter of the next, the first and the last beyond it).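

Among these compounds, at this aromatic carbon, opposite the ring nitrogen, chloro in place of methoxy gives the first step beyond the scatter in this assay, though only a modest one (a 2.1-fold higher number from compound 2 to compound 3 (0.31 log units; beyond the scatter)). Chloro in place of 1H-imidazol-1-yl gives no readable difference (a 1.0-fold higher number from compound 1 to compound 3 (0.01 log units; within the scatter)), so methoxy is set apart from chloro but not from 1H-imidazol-1-yl (a 2.0-fold lower number from compound 1 to compound 2 (0.30 log units; within the scatter)), and the three groups do not form a clean ranking. Nothing available explains the methoxy to chloro step.

From the compounds shown here alone, it remains open whether an amine, a carboxylic acid or a longer alkoxy chain such as propoxy at this carbon would stay within this narrow span of values. Going by these compounds, it is also open whether the methoxy to chloro step would hold with a group other than methylamino on the shared core.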